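The source may report more compounds than this note shows. Statements on the series, on what has been measured and on what is new or still open speak of the compounds shown alone.

Measured compounds:
- compound 1, `Nc1ccccc1NC(=O)/C=C/c1ccc(CSc2ccc(F)cc2)cc1` — "not determined" (no result reported)
- compound 2, `Nc1ccccc1NC(=O)c1ccc(CSc2cccc(F)c2)cc1` — 3280 nM
- compound 3, `COC(=O)c1ccccc1SCc1ccc(C(=O)Nc2ccccc2N)cc1` — 4490 nM

In a functional assay on SMMC-7721 cells (Homo sapiens) for antiproliferative activity, read by CCK-8 assay, with a stated time of 72 h (on this read-out lower numbers stand for stronger inhibition and higher numbers for weaker inhibition), compound 2 gives 3280 nM, the lowest of the two numbers at hand. Its nearest neighbour is compound 3, and the gap between compound 2 and compound 3 lies within the scatter, so the two cannot be told apart. Compound 4, `Nc1ccccc1NC(=O)c1ccc(CSCCc2ccccc2)cc1`, has not yet been measured. It differs from compound 2 in one place: phenethyl in place of 3-fluorophenyl on a sulfur. Within the data shown here, no step between measured compounds shows what such a swap on the sulfur does, so the expectation rests on the closeness of compound 2 and compound 3 alone. In this assay the step from compound 2 to compound 4 is expected to stay within the scatter, with no clear direction, which is an estimated 1.2-fold higher number from compound 2 to compound 4 (0.09 log units; within the scatter). Compound 4 is therefore expected to give about 4000 nM, in a range from 1500 nM to 11000 nM.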

Compound 4, half-maximal inhibitory concentration: 4880 nM
Beside the measured number, compound 4's estimate is 1.2-fold (0.09 log units) below it; the measured number falls inside the stated range.
By their numbers in this assay, from the lowest: compounds 2, 3 and 4 (each within the scatter of the next).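

Among these compounds, on the sulfur, phenethyl in place of 3-fluorophenyl gives a 1.5-fold higher number from compound 2 to compound 4 (0.17 log units; within the scatter) in this assay, the first step that tests a swap at this position. The two groups therefore cannot be told apart here, even though phenethyl has a saturated chain and no fluorine. No measured evidence bears on why this is so. Going by these compounds, it remains open whether a group with no aromatic ring at this position, such as an amine or a carboxylic acid on a longer chain, would give a step beyond the scatter.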